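Swapping azetidin-1-yl for thiophen-3-yl on a carbonyl carbon

The compounds below may be only part of what the source reports. "The series", "measured", "known", "first", "only" and "open" are said of these compounds alone.

Compound 1 `CC(C)(C)c1[nH]cnc1/C=c1\[nH]c(=O)/c(=C/c2cccc(C(=O)N3CCC3)c2)[nH]c1=O` has so far yielded no exact potency. In a functional assay on BXPC-3 cells (Homo sapiens) for antiproliferative activity, read by sulforhodamine B assay, with a stated time of 72 h (a lower number here means a stronger inhibitor, a higher number a weaker inhibitor), compound 1 reads > 500 nM, which is a limit of the assay and not a number. Compound 2 `O=C(c1cccc(/C=c2\[nH]c(=O)/c(=C/c3ccccn3)[nH]c2=O)c1)N1CCCCC1` gives > 500 nM, and this too is a limit. The evidence so far therefore amounts to the limit of > 500 nM in this assay, at which 2 of the 2 values shown sit.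

Compound 3 `CC(C)(C)c1[nH]cnc1/C=c1\[nH]c(=O)/c(=C/c2cccc(C(=O)c3ccsc3)c2)[nH]c1=O` departs from compound 1 in one place, with thiophen-3-yl in place of azetidin-1-yl on a carbonyl carbon. Among the measured compounds shown here, no pair of measured compounds shows what such a change does, so the expectation rests on the structural change alone and carries wide uncertainty. The replacement of the four-membered non-aromatic ring by a five-membered aromatic ring is nevertheless expected to bring a clear strengthening in this assay, well beyond the scatter. The estimated size of this change is an at least 20-fold lower number from compound 1 to compound 3 (1.30 log units; beyond the scatter). For compound 3 the expected value is 25 nM, with an estimated range from 4 nM to 200 nM.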

Compound 3, half-maximal inhibitory concentration: 1.56 nM
For compound 3 the middle estimate is 16-fold (1.20 log units) above the measured one, outside the stated range (below it).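

Compound 3 is the first compound here to give an exact number in this assay, which shows that a single change on the carbonyl carbon can move the read-out off the limit that had marked the series until now: the limit of > 500 nM in this assay, at which 2 of the 3 values shown sit.

Exchanging azetidin-1-yl for thiophen-3-yl at this place gives an at least 320-fold lower number from compound 1 to compound 3 (2.50 log units; beyond the scatter), with the rest of the structure unchanged, so the group on this carbonyl carbon has a large bearing on the read-out and the core of compound 1 alone does not decide it. Compound 1 gives > 500 nM, which is a limit of the assay and not a number, so the printed size of the step is a minimum.

Among the compounds shown here, the single pair changes the ring size, the ring type and the hetero atom together, so it cannot say which of these differences carries the gain. Going by these compounds, whether phenyl, furan-3-yl or thiophen-2-yl on the same carbonyl carbon would keep this strength remains open, as does the effect of thiophen-3-yl on the core of compound 2, which differs from compound 3 in more than one place.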